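This account rests on a few compounds, and the source may have more. Where it says the series, first, only, none or still open, it means among the compounds named here.

Working notes on the series.

Of the compounds shown here, two of the shared core have been measured in a functional assay on the whole organism (strain albino) with Mus musculus as the target, at a dose of 100 mg/kg by the intraperitoneal route; a higher number here means more inhibition at the dose given (going by the name of the read-out), a lower number less inhibition. Compound 1, `CCOc1ccc(NC(=O)Nn2c(CC)nc3ccccc3c2=O)cc1`, gives 50%. Compound 2, `CCc1nc2ccccc2c(=O)n1NC(=O)Nc1ccc(Cl)cc1`, gives 52%. Within the data shown here, the only step so far, a number 2 percentage points higher from compound 1 to compound 2 (within the scatter), shows that swapping the ethoxy for chloro on the aromatic carbon leaves the read-out where it was. On the two numbers in hand compound 2 has the higher figure, but its gap to compound 1 lies within the scatter, so no order can be read from it.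

The next compound, compound 3, `CCc1nc2ccccc2c(=O)n1NC(=O)Nc1ccc(F)cc1`, differs from compound 2 by fluoro in place of chloro on an aromatic carbon. Among the measured compounds shown here, only one measured step bears on a change at this position, and it was within the scatter; none of the measured steps exchanges one halogen for another. Nothing in the measured pairs suggests that a further change at this aromatic carbon moves the read-out, so the step of a number 4 percentage points lower from compound 2 to compound 3 (within the scatter) is expected to stay within the scatter, with no set direction. Compound 3 is therefore estimated at 48% in this assay, in a range from 34% to 62%.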

Compound 3, a percentage reported as inhibition, in the whole organism at one dose (the size of the read-out at that dose, not a potency): 51%
Compound 3: middle estimate off by 3 percentage points, on the low side; the measured number falls inside the stated range.
By their numbers in this assay, from the lowest: compounds 1, 3 and 2 (each within the scatter of the next).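

In this assay the exchange of one halogen for another at this position now has a measured step: a number 1 percentage points lower from compound 2 to compound 3 (within the scatter) and so fluoro in place of chloro, on an aromatic carbon para to a large group, leaves the read-out where it was. The ethoxy comparison adds a second step that stays flat, a number 1 percentage points higher from compound 1 to compound 3 (within the scatter) and with it all three pairs among ethoxy, chloro and fluoro lie within the scatter, so the three groups cannot be put in any order. No measurement is available that would explain this flat response.

The compounds shown leave open whether a clearly different group at this aromatic carbon, such as an amine, a carboxylic acid or a longer chain, would move the read-out beyond the scatter. Each number in this assay also gives only the size of the read-out at one dose and not a potency, so any difference among these compounds that would appear only at other doses remains unknown.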